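The source may report more compounds than this note shows. Statements on the series, on what has been measured and on what is new or still open speak of the compounds shown alone.

Measured so far, every value a limit and not a number:
Compound 1 `O=C(NNc1ccc(F)cc1)c1ccc(NS(=O)(=O)c2cnc(O)nc2O)cc1`: > 20000 nM
Compound 2 `Cc1cccc(NNC(=O)c2ccccc2NS(=O)(=O)c2cnc(O)nc2O)c1`: > 20000 nM
Compound 3 `O=C(NNC(=O)c1ccc(NS(=O)(=O)c2cnc(O)nc2O)cc1)c1ccc(F)cc1`: > 20000 nM

In a functional assay on MDA-MB-231 cells (Homo sapiens) for antiproliferative activity, read by MTT assay, with a stated time of 24 h (on this read-out lower numbers stand for stronger inhibition and higher numbers for weaker inhibition), compound 2 gives > 20000 nM, which is a limit, so it offers no number to step from. The whole set looks the same: the limit of > 20000 nM in this assay, at which 3 of the 3 values shown sit.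

Compound 4 `Cc1ccc(C(=O)NNC(=O)c2ccccc2NS(=O)(=O)c2cnc(O)nc2O)cc1` has not yet been measured. It differs from compound 2 by (4-methylphenyl)carbonyl in place of 3-methylphenyl on an amine nitrogen.

Within the data shown here, the one measured step of a similar kind, with (4-fluorophenyl)carbonyl in place of 4-fluorophenyl on an amine nitrogen, is a step that the two limits leave unreadable from compound 1 to compound 3. It gives no size to carry over, so no step beyond the scatter is expected in this assay, in either direction. The expectation rests on compound 3, which carries a carbonyl group of this kind and gives > 20000 nM, again a limit.

The estimated step is a step that the limit leaves unreadable from compound 2 to compound 4. Compound 4 is expected near 25000 nM, with an estimated range of 10000 nM to 50000 nM, and will most likely be reported only as a limit.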

Compound 4, half-maximal inhibitory concentration: > 20000 nM
Compound 4 gave a limit, no number; the forecaster's own chance of this, stated with the estimate: 85%; the middle value does not contradict the limit.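

Compound 2 and compound 4 each give only a limit and not a number, so the step between them cannot be read. The compounds shown leave open how far any of these changes shifts activity, for all of them share one result: the limit of > 20000 nM in this assay, at which 4 of the 4 values shown sit.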